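Replacing the propyl group with hydroxy on the amide nitrogen

The source may report more compounds than this note shows. Statements on the series, on what has been measured and on what is new or still open speak of the compounds shown alone.

Measured so far:
Compound 1 `CCC(C)N(Cc1cccs1)C(=O)COc1ccc(C)cc1`, 2000 nM
Compound 2 `Cc1ccc(OCC(=O)N(Cc2cccs2)c2ccncc2)cc1`, 52 nM
Compound 3 `CCCN(Cc1cccs1)C(=O)COc1ccc(C)cc1`, 40 nM

In an assay on HEK293 cells for agonist activity at transient receptor potential cation channel subfamily M member 8 (Homo sapiens), read by fluorescence and calcium flux, with a stated time of 15 min (on this read-out higher numbers stand for an effect only at larger amounts of compound and lower numbers for an effect already at smaller amounts), compound 3 gives the lowest number of the three. Compound 2 sits close by, with a 1.3-fold lower number from compound 2 to compound 3 (0.11 log units; within the scatter), while compound 1 lies far off, with a 50-fold lower number from compound 1 to compound 3 (1.70 log units; beyond the scatter). Compound 4 `Cc1ccc(OCC(=O)N(O)Cc2cccs2)cc1` is not yet measured. Its change from compound 3 is hydroxy in place of propyl on an amide-type nitrogen. The measured steps that touch this nitrogen are a 38-fold lower number from compound 1 to compound 2 (1.59 log units; beyond the scatter) and a 1.3-fold lower number from compound 2 to compound 3 (0.11 log units; within the scatter), so propyl and pyridin-4-yl give similar numbers, and only the branched sec-butyl stands apart. Going by the values given here, no measured compound carries hydroxy here, so the step is uncertain. A moderately higher number is expected for compound 4, namely 300 nM, between 50 nM and 3000 nM, a step of a 7.5-fold higher number from compound 3 to compound 4 (0.88 log units; beyond the scatter).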

Compound 4, half-maximal effective concentration: 8000 nM
Compound 4: the middle estimate sits 27-fold (1.43 log units) below what was measured; measured number above the stated range.
By their numbers in this assay, from the lowest: compounds 3 and 2 (each within the scatter of the next); then compound 1; then compound 4.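

In this assay, this amide-type nitrogen gives similar numbers with propyl and pyridin-4-yl, but hydroxy in their place pushes the number far up (a 200-fold higher number from compound 3 to compound 4 (2.30 log units; beyond the scatter); a 150-fold higher number from compound 2 to compound 4 (2.19 log units; beyond the scatter)). Even sec-butyl, the carbon group with the highest number here, does better than hydroxy (a 4.0-fold higher number from compound 1 to compound 4 (0.60 log units; beyond the scatter)), so compound 4 ends highest of the four. Nothing available explains this loss.

As far as these compounds go, it remains open whether a small group such as methoxy or an amine on this nitrogen would behave like hydroxy. From the compounds shown here alone, it is also open whether a longer straight chain such as butyl would stay close to propyl.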